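A few compounds are considered here, and "the series" means these few. Any claim that something is new, unique, unknown or untested is made for them only; others in the source may bear on it.

In a functional assay on HCT-116 cells (Homo sapiens) for antiproliferative activity, read by MTT assay, with a stated time of 72 h (on this read-out higher numbers stand for weaker inhibition and lower numbers for stronger inhibition), the measured compounds are
Compound 1 `NC1=NC2(CCSCC2)N(OCCCOc2ccc(Br)cc2)C(N)=N1` with 20 nM
Compound 2 `NC1=NC2(CCSCC2)N(OCCCOc2cc(Cl)c(Cl)cc2Cl)C(N)=N1` with 1 nM

Compound 2 holds the lower of the two numbers, and the gap to compound 1 lies beyond the scatter. Compound 3 `NC1=NC2(CCSCC2)N(OCCCOc2ccc(Cl)cc2)C(N)=N1` differs from compound 2 by 4-chlorophenyl in place of 2,4,5-trichlorophenyl on an oxygen on a saturated carbon and has 4-chlorophenyl in place of 2,4,5-trichlorophenyl on an oxygen on a saturated carbon. For the measured compounds named here, one measured step bears on this change. It is a 20-fold lower number from compound 1 to compound 2 (1.30 log units; beyond the scatter) and it is large, with 2,4,5-trichlorophenyl in place of 4-bromophenyl at the same place. Compound 3 gives up that same 2,4,5-trichlorophenyl group, so a large step back to a higher number is expected, beyond the scatter, towards compound 1 at 20 nM in this assay as the nearest guide. The expected step is a 20-fold higher number from compound 2 to compound 3 (1.30 log units; beyond the scatter) in size. The estimated value for compound 3 is 20 nM with 6 nM to 60 nM as its expected range.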

Compound 3, half-maximal inhibitory concentration: 10 nM
Compound 3: middle estimate off by 2.0-fold (0.30 log units), on the high side; low and high end bracket the measured number.
By their numbers in this assay, from the lowest: compound 2; then compounds 3 and 1 (each within the scatter of the next).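

In this assay, 4-chlorophenyl in place of 2,4,5-trichlorophenyl on the oxygen gives a 10-fold higher number from compound 2 to compound 3 (1.00 log units; beyond the scatter), so the earlier gap does not depend on the bromo group of compound 1. Chloro in place of bromo on the aromatic carbon gives a 2.0-fold lower number from compound 1 to compound 3 (0.30 log units; within the scatter), which leaves 4-chlorophenyl and 4-bromophenyl indistinguishable here, while 2,4,5-trichlorophenyl stands apart from both. Nothing available explains why the 2,4,5-trichlorophenyl group differs from these two groups.

As far as these compounds go, it remains open whether an unsubstituted phenyl group, or a phenyl group carrying methoxy or trifluoromethyl, would fall with compound 3 or with compound 2. Also open, from the compounds shown here alone, is how a longer chain on the oxygen would change the number with either 4-chlorophenyl or 2,4,5-trichlorophenyl in place.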